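Chloro for bromo in a cell growth inhibition series

A few compounds are considered here, and "the series" means these few. Any claim that something is new, unique, unknown or untested is made for them only; others in the source may bear on it.

Compound 1 `CC(=O)c1cccc(Nc2ccnc(SCC(=O)c3ccc(-c4ccccc4)cc3)n2)c1`: 12%
Compound 2 `CC(=O)c1cccc(Nc2ccnc(SCC(=O)c3ccc(C(F)(F)F)cc3)n2)c1`: 19%
Compound 3 `CC(=O)c1ccc(Nc2ccnc(SCC(=O)c3ccc(Br)cc3)n2)cc1`: 10%

All three compounds share a core and were tested in a functional assay on ACHN cells (Homo sapiens) for inhibition, read by sulforhodamine B assay, with a stated time of 48 h, tested at 10 uM; on this read-out lower numbers stand for less inhibition of growth and higher numbers for more inhibition of growth at the one concentration tested. Compound 3 stands at the low end of the three numbers, yet its gaps to compound 1 and compound 2 are both within the scatter, so no ordering among the three can be claimed; each simply shows weak growth inhibition at the tested concentration.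

Compound 4 `CC(=O)c1ccc(Nc2ccnc(SCC(=O)c3ccc(Cl)cc3)n2)cc1` has not been measured. It differs from compound 3 in one place: chloro in place of bromo on an aromatic carbon. The only measured step among these compounds, a number 7 percentage points higher from compound 1 to compound 2 (within the scatter), also swaps one group on the aromatic carbon of the carbon-only ring, and it stayed within the scatter. Going by the values given here, no measured step exchanges bromo for chloro, so nothing here points to a change beyond the scatter in this assay.

The expectation is therefore that compound 4 shows a step of a number 1 percentage points higher from compound 3 to compound 4 (within the scatter), in other words no movement beyond the scatter. Compound 4 is expected to give about 11% in this assay, with a likely range from 2% to 22%.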

Compound 4, percent growth inhibition at one concentration: 11%
Estimate against measurement, compound 4: no gap at the digits printed; low and high end bracket the measured number.
By their numbers in this assay, from the lowest: compounds 3, 4, 1 and 2 (each within the scatter of the next).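

In this assay, chloro in place of bromo on this aromatic carbon, para to a large group, gives a number 1 percentage points higher from compound 3 to compound 4 (within the scatter), so this is a direct one-place comparison of two halogens at this position, with compound 4 at 11% and no movement beyond the scatter. The earlier step, a number 7 percentage points higher from compound 1 to compound 2 (within the scatter), exchanged phenyl for trifluoromethyl on a different parent compound and could not show how bromo and chloro compare here; the new pair shows that this particular exchange, from 4-bromophenyl to 4-chlorophenyl, leaves growth inhibition at the one tested concentration weak. Nothing available here offers a measured explanation for this result.

The compounds shown leave open whether a quite different group on this aromatic carbon, such as an amine or a carboxylic acid, would move the number beyond the scatter. They also leave open whether bromo and chloro would still read alike at other concentrations or on other cells, since a single weak reading at one concentration says little about either.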